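Replacing a 1-phenylethyl with a 3-aminopropyl on the core

The source may report more compounds than this note shows. Statements on the series, on what has been measured and on what is new or still open speak of the compounds shown alone.

Measured compounds:
compound 1 `C[C@@H](Nc1c(C(=O)NCc2ccc(F)cc2)nc(Br)c2cccnc12)c1ccccc1`: > 20000 nM
compound 2 `N[C@H]1CC[C@H](NC(=O)c2nc(Br)c3cccnc3c2NCc2ccc(F)cc2)CC1`: 6600 nM

Compound 1 was tested in a functional assay on MDA-MB-435 cells (Homo sapiens) for cytotoxicity, read by MTT assay, with a stated time of 72 h; a lower number here means a stronger inhibitor, a higher number a weaker inhibitor. In this assay compound 1 gives > 20000 nM, which is a limit of the assay and not a number (the limit of > 20000 nM in this assay, at which 1 of the 2 values shown sits). Compound 2 gives 6600 nM in this assay, a measured value rather than a limit.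

Compound 3 `NCCCNc1c(C(=O)NCc2ccc(F)cc2)nc(Br)c2cccnc12` is not yet measured. It differs from compound 1 in one place: 3-aminopropyl in place of 1-phenylethyl on a nitrogen on an aromatic ring. Compound 3 thus carries an aminopropyl chain on the aromatic nitrogen where compound 1 has a branched aromatic group.

For the measured compounds named here, since compound 1 sits at a limit, no step to it is known. Compound 2, which also carries a free amine, gives 6600 nM, and this suggests that compound 3 could fall in a similar range. He therefore expects compound 3 to be a stronger inhibitor than compound 1 in this assay, with a step of an at least 2.5-fold lower number from compound 1 to compound 3 (0.39 log units; beyond the scatter), though the limit for compound 1 leaves the size uncertain. Compound 3 is estimated at 8000 nM, within 2000 nM to 30000 nM.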

Compound 3, half-maximal inhibitory concentration: 5000 nM
Compound 3: the middle estimate sits 1.6-fold (0.20 log units) above what was measured; the measured number falls inside the stated range.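

This position now has its first readable step: 3-aminopropyl in place of 1-phenylethyl on a nitrogen on an aromatic ring gives an at least 4.0-fold lower number from compound 1 to compound 3 (0.60 log units; beyond the scatter) in this assay. The group that enters has no ring and no defined stereocentre, so neither the six-membered aromatic ring nor the stereocentre of 1-phenylethyl is needed here for compound 3 to give a measured 5000 nM. Compound 1 stands at a limit, so the step has a lower bound but no known full size: the limit of > 20000 nM in this assay, at which 1 of the 3 values shown sits.

The change swaps the whole group at once, so the compounds shown cannot separate the part played by the terminal amine from that of the loss of the ring. A plain propyl chain, a 3-hydroxypropyl chain or a longer chain ending in an amine would bear on that question.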